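A few compounds are considered here, and "the series" means these few. Any claim that something is new, unique, unknown or untested is made for them only; others in the source may bear on it.

Compound 1 `C=C1C[C@]23C[C@@]1(O)CC[C@@H]2c1cccc(C)c1[C@@H]3Cn1cc(-c2ccc(C)cc2)nn1` carries a 4-methylphenyl group, and in a functional assay on HL-60 cells (Homo sapiens) for cytotoxicity, read by MTT assay, with a stated time of 4 days (a lower number here means a stronger inhibitor, a higher number a weaker inhibitor), compound 1 reaches only the limit of > 20000 nM. Compound 2 `COc1ccc(-c2cn(C[C@H]3c4c(ccc(O)c4C)[C@@H]4CC[C@@]5(C)C[C@]43CC5=O)nn2)cc1` likewise stops at the limit of > 20000 nM in this assay. Compound 3 `Cc1c(O)ccc2c1[C@H](Cn1cc(-c3ccccc3)nn1)[C@@]13CC(=O)[C@@](C)(CC[C@@H]21)C3` also ends at the limit of > 20000 nM in this assay. The step that the two limits leave unreadable from compound 2 to compound 3 therefore cannot be read. Compound 4 `C=C1C[C@]23C[C@@]1(O)CC[C@@H]2c1cccc(C)c1[C@@H]3Cn1cc(-c2ccccc2)nn1` differs from compound 1 by hydrogen in place of methyl on an aromatic carbon. Among the compounds with values here, the only measured step also swaps a substituent for hydrogen and stays unreadable, and since the limit of > 20000 nM in this assay, at which 3 of the 3 values shown sit, no step in this assay here has a measurable size. Compound 4 is therefore expected to sit at the limit as well, an estimated step that the limit leaves unreadable from compound 1 to compound 4 to a value around 40000 nM (range 15000 nM to 120000 nM).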

Compound 4, half-maximal inhibitory concentration: > 20000 nM
Compound 4 ended at the assay's limit (the forecaster's own chance of this, stated with the estimate: 85%); the middle value is on the limit's open side.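

Both compound 1 and compound 4 give only limits in this assay, so no size can be read for the change from 4-methylphenyl to phenyl: the limit of > 20000 nM in this assay, at which 4 of the 4 values shown sit. The compounds shown leave open which structural change, if any, would bring cytotoxicity within the assay's readable range.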